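This account rests on a few compounds, and the source may have more. Where it says the series, first, only, none or still open, it means among the compounds named here.

The work measures how strongly small molecules slow the growth of a human lung cancer cell line, read in a functional assay on A549 cells (Homo sapiens) for antiproliferative activity, read by sulforhodamine B assay, with a stated time of 72 h; a higher number here means a weaker inhibitor of growth, a lower number a stronger inhibitor of growth. Compound 1 `Cc1cc(=O)oc2cc(SCc3cccnc3)ccc12` gives > 35200 nM there, which is a limit of the assay rather than a measured number. Compound 2 `COc1cc(CSc2ccc3c(C)cc(=O)oc3c2)cc(OC)c1` gives > 29200 nM in this assay, again only a limit. Compound 3 `CCc1oc2c(C)c(OC)ccc2c(=O)c1Br` gives > 33600 nM in this assay, also a limit. So compound 3 stands among values that are all limits: one sits at the limit of > 29200 nM in this assay, at which 1 of the 3 values shown sits, one at the limit of > 33600 nM in this assay, at which 1 of the 3 values shown sits, and one at the limit of > 35200 nM in this assay, at which 1 of the 3 values shown sits, so none of the three compounds has shown measurable growth inhibition, and no ranking among them can be drawn.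

Compound 4 `CCc1oc2c(C)c(OC(C)C)ccc2c(=O)c1Br` is the next compound awaiting measurement. It differs from compound 3 in one place: isopropyl in place of methyl on an oxygen on an aromatic ring. Among the measured compounds shown here, no step between two measured compounds is available to guide the size of this change, so the expectation rests on compound 3 alone. Since compound 3 gave only > 33600 nM, the step that the limit leaves unreadable from compound 3 to compound 4 is expected to be none beyond the usual scatter, with the result most likely another limit. Compound 4 is therefore estimated at 40000 nM in this assay, within a range from 10000 nM to 120000 nM.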

Compound 4, concentration for 50% growth inhibition: > 30700 nM
Compound 4: no number, only a limit; the forecaster's own chance of this, stated with the estimate: 80%; the middle value is on the limit's open side.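

Compound 3 and compound 4 are both known only through limits, so no step can be read for the change from methoxy to isopropoxy. All four compounds shown give only limits in this assay, which leaves open whether they differ at all and what change in structure would give a measurable value.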